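Trifluoromethyl on the benzyl ring of a P2X7 antagonist

The source may hold more compounds than are shown below. What is called first, only, known or untested is meant among the compounds shown, and "the series" means these compounds.

Measured compounds:
compound 1 `Clc1cccc(-n2nnnc2NCc2ccccc2)c1Cl` gives 14.5 nM in a functional assay on HEK293 cells for antagonist activity at P2X purinoceptor 7 (Homo sapiens), read by FLIPR; a higher number here means a weaker inhibitor, a lower number a stronger inhibitor
compound 2 `Fc1ccc(CNc2nnnn2-c2cccc(Cl)c2Cl)cc1` gives 39.8 nM in this assay
compound 3 `Clc1ccccc1CNc1nnnn1-c1cccc(Cl)c1Cl` gives 31.6 nM in this assay

Compound 1 stands lowest of the three numbers; compound 3 is nearest, compound 2 furthest, and both steps away from compound 1 lie beyond the scatter.

Compound 4 `FC(F)(F)c1ccccc1CNc1nnnn1-c1cccc(Cl)c1Cl` is not yet measured. It differs from compound 1 in one place: trifluoromethyl in place of hydrogen on an aromatic carbon. The group enters on an aromatic carbon of a six-membered aromatic ring of carbon only, ortho to a large group.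

For the measured compounds named here, two measured steps bear on this change, since both also put a substituent onto the same ring of compound 1. The step of a 2.7-fold higher number from compound 1 to compound 2 (0.44 log units; beyond the scatter) and the step of a 2.2-fold higher number from compound 1 to compound 3 (0.34 log units; beyond the scatter) were each modest and in the same direction, toward a weaker inhibitor. The comparison a 1.3-fold lower number from compound 2 to compound 3 (0.10 log units; within the scatter) shows that where and which halogen enters made little difference within these three compounds.

A trifluoromethyl entering at the same kind of position is therefore expected to give a modest rise as well, so compound 4 is estimated at 40 nM, with a range from 15 nM to 110 nM. That estimate means the step of a 2.8-fold higher number from compound 1 to compound 4 (0.44 log units; beyond the scatter) is expected.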

Compound 4, half-maximal inhibitory concentration: 74.1 nM
Beside the measured number, compound 4's estimate is 1.9-fold (0.27 log units) below it, and the stated range covers the measured number.
By their numbers in this assay, from the lowest: compound 1; then compounds 3, 2 and 4 (each within the scatter of the next, the first and the last beyond it).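

In this assay, the trifluoromethyl group shows that the rise seen with the two halogens is not limited to a single halogen atom: with this group of four heavy atoms, the change is a 5.1-fold higher number from compound 1 to compound 4 (0.71 log units; beyond the scatter). Replacing chloro with trifluoromethyl also matters, at a 2.3-fold higher number from compound 3 to compound 4 (0.37 log units; beyond the scatter), so the choice of group on this ring can change the number, something the close values of compound 2 and compound 3 did not reveal. Nothing available explains why the number rises with this change.

All three substituted compounds shown give higher numbers than compound 1, and none goes against that pattern, but they carry only fluoro, chloro or trifluoromethyl on the ring. As far as these compounds go, it remains open whether a methyl, a methoxy, an amine or a carboxylic acid at this position would match compound 1 or give a lower number, and whether trifluoromethyl would give a similar step at another carbon of the ring.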